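From a Naphthyl Ether to an Ethoxybenzyl Side Chain

A few compounds are considered here, and "the series" means these few. Any claim that something is new, unique, unknown or untested is made for them only; others in the source may bear on it.

Of the compounds shown here, three built on one shared core have been tested in an assay on HEK293 cells for displacement of a labelled ligand from Melanocortin receptor 4 (Homo sapiens); on this read-out lower numbers stand for stronger inhibition and higher numbers for weaker inhibition. Compound 1 `CC(C)C[C@H](N)c1cc(C(F)(F)F)ccc1N1CCN(C(=O)COc2cccc(Cl)c2Cl)CC1` gives 2500 nM. Compound 2 `Cc1cc(CC(C)C(=O)N2CCN(c3ccc(C(F)(F)F)cc3[C@@H](N)CC(C)C)CC2)ccc1Cl` gives 71 nM. Compound 3 `CC(C)C[C@H](N)c1cc(C(F)(F)F)ccc1N1CCN(C(=O)COc2cccc3ccccc23)CC1` gives 2600 nM, the highest of the three numbers; against compound 1 the difference is a 1.0-fold higher number from compound 1 to compound 3 (0.02 log units; within the scatter), whereas a 37-fold higher number from compound 2 to compound 3 (1.56 log units; beyond the scatter) places it far from compound 2.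

Compound 4 `CCOc1cccc(CC(C)C(=O)N2CCN(c3ccc(C(F)(F)F)cc3[C@@H](N)CC(C)C)CC2)c1` awaits measurement. Its difference from compound 3 is 1-(3-ethoxybenzyl)ethyl in place of ((naphthalen-1-yl)oxy)methyl on a carbonyl carbon.

Two measured steps speak to this exchange. The closest is a 37-fold higher number from compound 2 to compound 3 (1.56 log units; beyond the scatter), which shows that trading a 1-(4-chloro-3-methylbenzyl)ethyl group for ((naphthalen-1-yl)oxy)methyl on the carbonyl carbon raised the number sharply; in the same spirit, a 35-fold lower number from compound 1 to compound 2 (1.55 log units; beyond the scatter) shows the benefit of the benzyl-ethyl type of group over an oxygen-linked aryl. Among the measured compounds shown here, compound 4 carries the same kind of chain as compound 2, though with a 3-ethoxyphenyl ring rather than the 4-chloro-3-methylphenyl ring, so no measured step covers that ring difference directly.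

For compound 4 the expected step is a 13-fold lower number from compound 3 to compound 4 (1.11 log units; beyond the scatter). Compound 4 is therefore estimated at 200 nM, with a likely range from 50 nM to 800 nM.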

Compound 4, inhibition constant: 2200 nM
For compound 4 the middle estimate is 11-fold (1.04 log units) below the measured one, and the stated range ends below it.
By their numbers in this assay, from the lowest: compound 2; then compounds 4, 1 and 3 (each within the scatter of the next).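

The kind of chain on the carbonyl carbon does not settle the result alone: in this assay the ring at the end of the chain matters greatly, as 3-ethoxyphenyl in place of 4-chloro-3-methylphenyl gives a 31-fold higher number from compound 2 to compound 4 (1.49 log units; beyond the scatter) on an otherwise unchanged structure. With the 3-ethoxyphenyl ring, the 1-benzylethyl type of chain offers no measurable advantage over either oxygen-linked group, with a 1.2-fold lower number from compound 3 to compound 4 (0.07 log units; within the scatter) against the naphthalen-1-yl ether and a 1.1-fold lower number from compound 1 to compound 4 (0.06 log units; within the scatter) against the 2,3-dichlorophenyl ether, so the large gain seen earlier holds for compound 2 and does not extend to compound 4. Nothing measured here explains why this ring exchange has so large an effect.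

As far as these compounds go, it remains open whether the chlorine or the methyl group of compound 2 accounts for its lower number, which a plain 4-chlorophenyl or 3-methylphenyl ring on the same chain would help to separate. From the compounds shown here alone, it is also open how much the ethoxy group itself contributes, a question that an unsubstituted phenyl ring or a 3-methoxyphenyl ring in its place could address.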